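Fluorine added to a diaryl ether thiosemicarbazone: lipophilicity expected

This account rests on a few compounds, and the source may have more. Where it says the series, first, only, none or still open, it means among the compounds named here.

Measured so far:
Compound 1 `S=C(N/N=C/c1ccc(Oc2ccc3ccccc3c2)cc1)Nc1ccccc1` gives 6.07 in a physicochemical assay for lipophilicity, in phosphate buffer, measured as octanol-water partition, with a stated time of 24 h; on this read-out lower numbers stand for lower lipophilicity and higher numbers for higher lipophilicity.
Compound 2 `S=C(N/N=C/c1ccc(Oc2ccc(Cl)cc2)cc1)Nc1ccccc1` gives 5.52 in this assay.

Within the data shown here, compound 1 stands highest of the two numbers; the only other number, that of compound 2, lies lower by an amount beyond the usual scatter. Compound 3 `Fc1ccc(NC(=S)N/N=C/c2ccc(Oc3ccc4ccccc4c3)cc2)cc1` differs from compound 1 in one place: fluoro in place of hydrogen on an aromatic carbon. Among the measured compounds shown here, no measured pair shows this exchange, so nothing here sets its size directly. The step is expected to be a small rise, a number 0.13 log units higher from compound 1 to compound 3 (within the scatter), not clearly beyond the scatter. Compound 3 is therefore estimated at 6.2, with a range from 5.9 to 6.5.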

Compound 3, partition coefficient: 6.2
The estimate for compound 3 equals the measured number at the digits printed; low and high end bracket the measured number.
By their numbers in this assay, from the lowest: compound 2; then compounds 1 and 3 (each within the scatter of the next).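

The step from anilino to (4-fluorophenyl)amino reads a number 0.13 log units higher from compound 1 to compound 3 (within the scatter) in this assay and so shows that, at this place para to a large group, fluoro in place of hydrogen leaves the two compounds indistinguishable. Compound 1 and compound 2 differ in more than one place, so they gave no reading of this position. No measurement at hand accounts for the size of this step.

As far as these compounds go, whether an amine or a carboxylic acid at this place would give a step beyond the scatter remains open. So does whether fluoro would give a similar step on the core of compound 2.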